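The compounds below may be only part of what the source reports. "The series", "measured", "known", "first", "only" and "open" are said of these compounds alone.

Of the compounds shown here, two with a shared core have so far been tested in a functional assay on MCF7 cells (Homo sapiens) for antiproliferative activity, read by MTT assay, with a stated time of 72 h (on this read-out higher numbers stand for weaker inhibition and lower numbers for stronger inhibition), and they differ in the group on an amine nitrogen in a ring. Compound 1 `Nc1nc(N)c2cc(CSC(=S)N3CCN(C4CCCCC4)CC3)ccc2n1`, which carries cyclohexyl there, gives 6800 nM. Compound 2 `Cc1ccccc1N1CCN(C(=S)SCc2ccc3nc(N)nc(N)c3c2)CC1`, which carries 2-methylphenyl, gives 4230 nM. Going by the values given here, these are the only two numbers available, and they lie within the scatter of each other, so compound 2 stands level with its sole neighbour.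

Compound 3 `Nc1nc(N)c2cc(CSC(=S)N3CCN(c4ccc(Cl)cc4)CC3)ccc2n1` keeps the shared core and changes that same group again: 4-chlorophenyl in place of 2-methylphenyl on an amine nitrogen in a ring. In words, 4-chlorophenyl takes the place of 2-methylphenyl. Among the compounds with values here, the one measured step that bears on this is a 1.6-fold lower number from compound 1 to compound 2 (0.21 log units; within the scatter), a swap at the same place that did not move the number beyond the scatter. Within the data shown here, a single step is thin evidence, and no measured compound carries 4-chlorophenyl. No step beyond the scatter is therefore expected in this assay, and no direction can be named. The estimated change is a 1.1-fold higher number from compound 2 to compound 3 (0.03 log units; within the scatter). For compound 3 the expected value is 4500 nM, with an estimated range of 2000 nM to 10000 nM.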

Compound 3, half-maximal inhibitory concentration: 4880 nM
Estimate against measurement, compound 3: 1.1-fold (0.04 log units) below; measured number inside the range.
By their numbers in this assay, from the lowest: compounds 2, 3 and 1 (each within the scatter of the next).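

Putting 4-chlorophenyl in place of 2-methylphenyl on the amine nitrogen in the ring gives a 1.2-fold higher number from compound 2 to compound 3 (0.06 log units; within the scatter), so exchanging one substituted aromatic ring for another leaves the number in this assay within the scatter. Going by these compounds alone, the comparison with the carbon-only non-aromatic ring of compound 1 gives a 1.4-fold lower number from compound 1 to compound 3 (0.14 log units; within the scatter), which adds a second step within the scatter, and all three groups at this place now sit level, with no compound among the three going against that. No measurement at hand accounts for this closeness of the numbers.

All three groups shown are carbon rings of similar size with no hydrogen-bond donors or acceptors, so it remains open whether a carboxylic acid, an amine on a longer chain, or a much smaller group such as methyl on this nitrogen would move the number beyond the scatter. The compounds shown also leave open how a plain phenyl would compare, and what a change at any other place on the shared core would do.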